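A few compounds are considered here, and "the series" means these few. Any claim that something is new, unique, unknown or untested is made for them only; others in the source may bear on it.

Series values in a functional assay for inhibition, with Homo sapiens as the target; on this read-out lower numbers stand for stronger inhibition and higher numbers for weaker inhibition:
Compound 1 `COc1cc(OC)c(C(=O)/C=C/c2ccc(Cl)cc2)c(OC)c1`: 970 nM
Compound 2 `COc1cc(OC)c(C(=O)/C=C/c2c(Cl)cccc2Cl)c(OC)c1`: 1090 nM
Compound 3 `COc1cc(OC)c(C(=O)/C=C/c2ccncc2)c(OC)c1`: 592 nM

Compound 3 is not separated from the other two compounds on these numbers. The measured steps to it are a 1.6-fold lower number from compound 1 to compound 3 (0.21 log units; within the scatter) and a 1.8-fold lower number from compound 2 to compound 3 (0.27 log units; within the scatter).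

Next in the series is compound 4 `COc1cc(OC)c(C(=O)/C=C/c2ccccn2)c(OC)c1`, which keeps the core of compound 3 and differs only as follows: pyridin-2-yl in place of pyridin-4-yl on a double-bonded chain carbon bound to a double-bonded chain carbon. This places pyridin-2-yl in place of pyridin-4-yl on a double-bonded chain carbon bound to a double-bonded chain carbon.

Among the compounds with values here, no measured step exchanges one pyridinyl group for another. The closest evidence comes from changes at the same place: a 1.1-fold higher number from compound 1 to compound 2 (0.05 log units; within the scatter), together with the two steps above. All three stay within the scatter, so for this assay no step beyond the scatter is expected here, and no direction can be supported. The expected step is a 1.2-fold higher number from compound 3 to compound 4 (0.07 log units; within the scatter). For compound 4 the estimate is 700 nM, with an expected range of 280 nM to 1750 nM.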

Compound 4, half-maximal inhibitory concentration: 596 nM
Compound 4: middle estimate off by 1.2-fold (0.07 log units), on the high side; the range from low to high includes it.
By their numbers in this assay, from the lowest: compounds 3, 4, 1 and 2 (each within the scatter of the next).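

In this assay, the exchange of pyridin-4-yl for pyridin-2-yl on a double-bonded chain carbon bound to a double-bonded chain carbon gives a 1.0-fold higher number from compound 3 to compound 4 (0.00 log units; within the scatter), so the two attachments of the pyridine ring are not told apart here. Pyridin-2-yl is likewise not separated from the chlorinated aryl groups, with a 1.6-fold lower number from compound 1 to compound 4 (0.21 log units; within the scatter) and a 1.8-fold lower number from compound 2 to compound 4 (0.26 log units; within the scatter). No measurement is at hand that would account for this result.

As far as these compounds go, every step at this place lies within the scatter, so it remains open whether any exchange here can shift the number in this assay. Pyridin-3-yl would complete the pyridinyl set, while a carboxylic acid or an amine on a longer chain at this carbon would test a much larger change.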